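Swapping an amine for an oxime on the shared core

The source may report more compounds than this note shows. Statements on the series, on what has been measured and on what is new or still open speak of the compounds shown alone.

Compound 1 `CC(=O)OC/C1=C/C[C@](C)(CCC=C(C)C)/C=C/[C@@H](OC(=O)C=C(C)C)[C@](C)(OC(C)=O)/C=C/C1=O`: 15100 nM
Compound 2 `CCN(CC)C/C1=C/C[C@](C)(CCC=C(C)C)/C=C/[C@@H](OC(=O)C=C(C)C)[C@](C)(O)/C=C/C1=O`: 130 nM
Compound 3 `CC(C)=CCC[C@]1(C)/C=C/[C@@H](OC(=O)C=C(C)C)[C@](C)(O)CCC(=O)/C(CO)=C\C1`: > 40000 nM (a limit, not a number)

In a functional assay on A549 cells (Homo sapiens) for antiproliferative activity, read by MTT assay, with a stated time of 48 h (a higher number here means a weaker inhibitor, a lower number a stronger inhibitor), compound 2 gives 130 nM, the lowest number shown; compound 1 gives 15100 nM, a higher value that lies beyond the scatter. For compound 3, this assay reports only a limit, > 40000 nM. Compound 4 `CO/N=C/C1=C/C[C@](C)(CCC=C(C)C)/C=C/[C@@H](OC(=O)C=C(C)C)[C@](C)(O)/C=C/C1=O` has not been measured. It differs from compound 2 in one place: a group of 4 heavy atoms (2 carbon, 1 nitrogen, 1 oxygen; no ring) in place of a group of 6 heavy atoms (5 carbon, 1 nitrogen; no ring), on a double-bonded ring carbon. Among the compounds with values here, no step between measured compounds that differ in a single place is available, so the expectation rests on compound 2 alone. A weakening step beyond the scatter is expected, a 15-fold higher number from compound 2 to compound 4 (1.19 log units; beyond the scatter). Compound 4 is estimated at 2000 nM, with a range from 300 nM to 15000 nM.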

Compound 4, half-maximal inhibitory concentration: 3470 nM
Compound 4: the middle estimate sits 1.7-fold (0.24 log units) below what was measured; measured number inside the range.
By their numbers in this assay, from the lowest: compound 2; then compound 4; then compound 1. At a limit, above all of these: compound 3.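

In this assay, the double-bonded ring carbon proves sensitive to this swap: the oxime in place of the (diethylamino)methyl group gives a 27-fold higher number from compound 2 to compound 4 (1.43 log units; beyond the scatter). Within the data shown here, the earlier compounds held no pair differing in one place, so this is the first direct reading of a change at this position, and the amine-bearing compound 2 comes out ahead of compound 4. Nothing measured here accounts for the size of this step.

Going by these compounds, whether this particular amine is required remains open. A dimethylamino or morpholine group on the same carbon would test that.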